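This account rests on a few compounds, and the source may have more. Where it says the series, first, only, none or still open, it means among the compounds named here.

Compound 1 `Cc1ccc(-c2nn(-c3ccccc3)cc2-c2nc3ccccc3n2S(=O)(=O)c2ccc(Br)cc2)cc1`: 3040 nM
Compound 2 `O=S(=O)(c1ccc(F)cc1)n1c(-c2cn(-c3ccccc3)nc2-c2ccc(F)cc2)nc2ccccc21`: 3520 nM

Both numbers come from a functional assay on HepG2 cells (Homo sapiens) for antiproliferative activity, read by MTT assay, with a stated time of 24 h; on this read-out higher numbers stand for weaker inhibition and lower numbers for stronger inhibition. There, compound 2 gives 3520 nM, which lies within the usual scatter of compound 1 at 3040 nM, so the two cannot be told apart.

The next compound, compound 3 `O=S(=O)(c1ccc(Br)cc1)n1c(-c2cn(-c3ccccc3)nc2-c2ccc(F)cc2)nc2ccccc21`, has not been measured yet. It departs from compound 2 by one change: bromo in place of fluoro on an aromatic carbon. In words, this is bromo in place of fluoro on an aromatic carbon, which turns the (4-fluorophenyl)sulfonyl into (4-bromophenyl)sulfonyl.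

For the measured compounds named here, no measured pair shows this swap alone, so the expectation rests on thin evidence. Going by the values given here, with compound 1 at 3040 nM and compound 2 at 3520 nM, the only numbers available sit close together, and no step beyond the scatter is expected in this assay. The expected change is a 1.1-fold lower number from compound 2 to compound 3 (0.04 log units; within the scatter). For compound 3 the estimated value is 3200 nM, with an expected range of 1700 nM to 6000 nM.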

Compound 3, half-maximal inhibitory concentration: 2550 nM
Compound 3: the middle estimate sits 1.3-fold (0.10 log units) above what was measured; the measured number falls inside the stated range.
By their numbers in this assay, from the lowest: compounds 3, 1 and 2 (each within the scatter of the next).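

With bromo in place of fluoro on the aromatic carbon of the (4-fluorophenyl)sulfonyl group, this assay shows a 1.4-fold lower number from compound 2 to compound 3 (0.14 log units; within the scatter) and so does not separate the two halogens at this position. At a second place on the molecule, fluoro in place of methyl on an aromatic carbon gives a 1.2-fold lower number from compound 1 to compound 3 (0.08 log units; within the scatter) and so does not separate these two groups in this assay either. No measurement shown here offers an explanation for these results.

As far as these compounds go, whether this sulfonyl ring would respond to a group other than a halogen remains open, since an amine, a carboxylic acid or a longer chain in that spot could give a quite different number. The compounds shown also leave open whether the bromo and fluoro pair would stay this close on other cell lines.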